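Furan-2-yl in place of 2-methoxyphenyl: cytotoxicity outlook

A few compounds are considered here, and "the series" means these few. Any claim that something is new, unique, unknown or untested is made for them only; others in the source may bear on it.

Compound 2 `CCn1cc(C(=O)N2N=C(c3cc4ccccc4o3)CC2c2ccccc2OC)c(=O)c2ccc(C)nc21` was tested in an ADME assay on Vero cells (Chlorocebus sabaeus) for cytotoxicity, read by MTT assay, with a stated time of 72 h; on this read-out higher numbers stand for weaker inhibition and lower numbers for stronger inhibition. In this assay compound 2 gives only a limit, > 187000 nM. Compound 1 `O=C(c1ccncc1)N1N=C(c2cc3ccccc3o2)CC1c1ccco1` likewise gives only a limit in this assay, > 208000 nM. Going by the values given here, the two values sit at the limits the limit of > 187000 nM in this assay, at which 1 of the 2 values shown sits, and (the limit of > 208000 nM in this assay, at which 1 of the 2 values shown sits), so no measured step between them exists. Compound 3 `CCn1cc(C(=O)N2N=C(c3cc4ccccc4o3)CC2c2ccco2)c(=O)c2ccc(C)nc21` differs from compound 2 by furan-2-yl in place of 2-methoxyphenyl on a saturated ring carbon. Compound 1 also carries furan-2-yl and sits at a limit, so compound 3 is expected to stay at a limit as well. The expected step that the limit leaves unreadable from compound 2 to compound 3 is none beyond the scatter. The estimate for compound 3 is 200000 nM, ranging from 120000 nM to 400000 nM.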

Compound 3, half-maximal inhibitory concentration: > 185000 nM
Compound 3: no number, only a limit; the forecaster's own chance of this, stated with the estimate: 85%; the middle value is on the limit's open side.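

In this assay compound 2 and compound 3 both give only limits, so no step can be read between them. The compounds shown leave open whether furan-2-yl in place of 2-methoxyphenyl changes the inhibition at all.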